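This account rests on a few compounds, and the source may have more. Where it says the series, first, only, none or still open, it means among the compounds named here.

Within the data shown here, in an ADME assay on MCF7-DOX cells (Homo sapiens) for cytotoxicity, read by MTT assay, with a stated time of 48 h (on this read-out lower numbers stand for stronger inhibition and higher numbers for weaker inhibition), compound 1 `COc1cc(OC)c(C(=O)/C=C/c2ccc(Cl)cc2)c(O)c1CC=C(C)C` gives 43400 nM and compound 2 `COc1cc(OC)c(C(=O)/C=C/c2ccc(N3CCNCC3)cc2)c(O)c1CC=C(C)C` gives 57800 nM, so compound 2 stands within the scatter of the only other measured compound. Compound 3 `COc1cc(OC)c(C(=O)/C=C/c2ccc(N(C)C)cc2)c(O)c1CC=C(C)C` keeps the shared core and differs from compound 2 by dimethylamino in place of piperazin-1-yl on an aromatic carbon, with dimethylamino in place of piperazin-1-yl on an aromatic carbon. Among the measured compounds shown here, one measured step bears on this change, as chloro gave way to piperazin-1-yl on that carbon: a 1.3-fold higher number from compound 1 to compound 2 (0.12 log units; within the scatter). On that basis, an estimated 1.2-fold lower number from compound 2 to compound 3 (0.08 log units; within the scatter) is expected, with no shift beyond the scatter in either direction. For compound 3 the estimated value is 48000 nM, within an expected range of 22000 nM to 100000 nM.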

Compound 3, half-maximal inhibitory concentration: > 100000 nM
Compound 3 was reported as a limit; the forecaster's own chance of this, stated with the estimate: 10%; at least 2.0-fold (0.31 log units) between middle value and limit.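

At this aromatic carbon, the earlier swap of chloro for piperazin-1-yl stayed within the scatter, but dimethylamino does separate from chloro in this assay: an at least 2.3-fold higher number from compound 1 to compound 3 (0.36 log units; beyond the scatter). Against piperazin-1-yl only a floor can be read, and it does not clear the scatter: an at least 1.7-fold higher number from compound 2 to compound 3 (0.23 log units; that floor lies within the scatter). Compound 3 is therefore held as a limit and not as a number: the limit of > 100000 nM in this assay, at which 1 of the 3 values shown sits.

From the compounds shown here alone, how far compound 3 truly lies from the other two stays open. So does what a morpholine ring or a primary amine would give on this same carbon.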